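Aryl swap on a piperazine: a step from an unreadable limit

The source may hold more compounds than are shown below. What is called first, only, known or untested is meant among the compounds shown, and "the series" means these compounds.

compound 1, `S=c1oc(-c2ccc3c(c2)OCCO3)nn1CN1CCN(c2ccc(Cl)cc2)CC1` — > 50000 nM
compound 2, `COc1ccc(N2CCN(Cn3nc(-c4ccc5c(c4)OCCO5)oc3=S)CC2)cc1` — > 50000 nM

In a functional assay on HeLa cells (Homo sapiens) for antiproliferative activity, read by MTT assay, with a stated time of 48 h (a higher number here means a weaker inhibitor, a lower number a stronger inhibitor), compound 1 gives only the limit > 50000 nM. Compound 2 likewise gives only the limit > 50000 nM in this assay, so compound 2 stands at the limit and nowhere else. Hence a step that the two limits leave unreadable from compound 1 to compound 2 cannot be sized. Compound 3, `Cc1ccc(N2CCN(Cn3nc(-c4ccc5c(c4)OCCO5)oc3=S)CC2)c(C)c1`, differs from compound 2 by 2,4-dimethylphenyl in place of 4-methoxyphenyl on an amine nitrogen in a ring. Among the compounds with values here, the only measured step bearing on it is unreadable, and both measured values sit at the limit of > 50000 nM in this assay, at which 2 of the 2 values shown sit. Compound 3 is therefore expected to sit near that limit, estimated at 50000 nM, with a range from 20000 nM to 120000 nM. The expected step of a number no higher from compound 2 to compound 3 (the limit leaves the size open) is none beyond the scatter.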

Compound 3, half-maximal inhibitory concentration: > 50000 nM
Compound 3: no number, only a limit (the forecaster's own chance of this, stated with the estimate: 75%); the middle value sits exactly at the limit.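

Compound 3 gives only a limit, > 50000 nM, in this assay. Within the data shown here, no step among compound 1, compound 2 and compound 3 can be read. How the aryl group on the amine nitrogen bears on activity stays open, with all three compounds resting at one point: the limit of > 50000 nM in this assay, at which 3 of the 3 values shown sit.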